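A Bare Phenol After Three Limits

The compounds below may be only part of what the source reports. "The series", "measured", "known", "first", "only" and "open" are said of these compounds alone.

Three esters share one core, and none yields a number in a functional assay on HepG2 cells (Homo sapiens) for cytotoxicity, with a stated time of 72 h; on this read-out lower numbers stand for an effect already at smaller amounts and higher numbers for an effect only at larger amounts of compound. Compound 1 `CCOC(=O)/C(C)=C/c1cc(/C=C/[C@](C)(/C=C/c2ccc(OC)cc2)CCC=C(C)C)ccc1O` gives > 52000 nM, which is a limit. Compound 2 `COc1ccc(/C=C/[C@@](C)(/C=C/c2ccc(O)c(/C=C/C(=O)OC(C)(C)C)c2)CCC=C(C)C)cc1` gives > 52000 nM, also a limit. Compound 3 `COc1ccc(/C=C/[C@@](C)(/C=C/c2ccc(O)c(/C=C/C(=O)OCc3ccccc3)c2)CCC=C(C)C)cc1` gives > 26000 nM, again a limit, so it stands without a true value.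

Compound 4 `COc1ccc(/C=C/[C@@](C)(/C=C/c2ccc(O)cc2)CCC=C(C)C)cc1` has hydrogen in place of 2-(benzyloxycarbonyl)ethenyl on an aromatic carbon, ortho to a hydroxy group: hydrogen in place of 2-(benzyloxycarbonyl)ethenyl on an aromatic carbon.

Two measured changes touch this same place: a step that the two limits leave unreadable from compound 1 to compound 2, and a step that the two limits leave unreadable from compound 1 to compound 3. A third changes only the ester group: a step that the two limits leave unreadable from compound 2 to compound 3. None provides a size to carry over, and none removes the whole group as this change does. Among the measured compounds shown here, no step of known size can therefore be expected, and the direction remains open. The estimated step is a step that the limit leaves unreadable from compound 3 to compound 4, and this assay may again report only a limit. Compound 4 is expected near 32000 nM, with an estimated range of 12000 nM to 60000 nM.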

Compound 4, half-maximal effective concentration: > 52000 nM
Compound 4: a limit, no number; the forecaster's own chance of this, stated with the estimate: 55%; at least 1.6-fold (0.21 log units) between middle value and limit.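

In this assay compound 4 gives > 52000 nM, which is a limit. Among the compounds shown here, all four results are limits, so no step from compound 1, compound 2 or compound 3 to compound 4 can be read. The compounds shown leave open whether removing the ester-bearing group changes cytotoxicity at all.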